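The source may hold more compounds than are shown below. What is called first, only, known or untested is meant among the compounds shown, and "the series" means these compounds.

Compound 1 `O=C(CCCc1ccccc1)Nc1nc2ccc(Cl)cc2c(=O)s1` belongs to a small set of amides built on one shared core. In an assay on CHO cells for displacement of a labelled ligand from adenosine receptor A3 (Homo sapiens), read by scintillation counting, with a stated time of 60 min (a lower number here means a stronger inhibitor, a higher number a weaker inhibitor), compound 1 gives > 1000 nM, which is a limit of the assay rather than a number. Compound 2 `O=C(COc1cccc(Cl)c1)Nc1nc2ccccc2c(=O)s1` carries a different acid part on the same core, and in this assay compound 2 gives > 1000 nM, again a limit and not a number. Going by the values given here, compound 3 `COc1cccc(/C=C/CC(=O)Nc2nc3ccccc3c(=O)s2)c1`, with an unsaturated linker to its aromatic ring, is the only member with a measured number: in this assay compound 3 gives 115 nM. So compound 1 stands at the limit, sharing that position with compound 2, a situation summed up as the limit of > 1000 nM in this assay, at which 2 of the 3 values shown sit, while compound 3 alone lies inside the measured range.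

Compound 4 `O=C(CCCc1ccccc1)Nc1nc2ccc(Br)cc2c(=O)s1` differs from compound 1 in one place: bromo in place of chloro on an aromatic carbon. Among the compounds with values here, no pair of measured compounds in this set differs in just one place, so this step has no measured precedent here. The change is small in what it counts, and the expected step is a step that the limit leaves unreadable from compound 1 to compound 4, a shift probably no larger than the scatter. Compound 4 is estimated at 2500 nM, with a range from 700 nM to 10000 nM. Compound 4 is expected, most probably, to be reported again as a limit.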

Compound 4, inhibition constant: > 1000 nM
Compound 4: a limit, no number; the forecaster's own chance of this, stated with the estimate: 75%; the middle value does not contradict the limit.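

In this assay compound 4 gives > 1000 nM, which is a limit and not a number. Compound 1 also stands at a limit, so no step can be read between compound 1 and compound 4. The compounds shown leave open whether bromo and chloro differ at all in their effect on binding on the shared core.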